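From methoxy to pyridin-3-yl on compound 2

The source may hold more compounds than are shown below. What is called first, only, known or untested is meant among the compounds shown, and "the series" means these compounds.

- compound 1 `CCCCOc1cccc(OCc2[nH]c3ccccc3c(=O)c2C)c1`: 4.7 nM
- compound 2 `COc1ccc2[nH]c(COc3cccc(OCC4CCOCC4)c3)c(C)c(=O)c2c1`: > 10000 nM (a limit)

In a functional assay on HUVEC cells (Homo sapiens) for inhibition, using NADPH, with a stated time of 2 h (a lower number here means a stronger inhibitor, a higher number a weaker inhibitor), compound 2 gives > 10000 nM as its reading, and this is a limit of the assay and not a number. Compound 3 `Cc1c(COc2cccc(OCC3CCOCC3)c2)[nH]c2ccc(-c3cccnc3)cc2c1=O` carries pyridin-3-yl in place of methoxy on an aromatic carbon. Within the data shown here, no measured step shows what this change does. Compound 1 reaches 4.7 nM in the same test, so strong inhibition is possible among these compounds. A moderate gain in inhibition is expected, with an estimated step of an at least 6.6-fold lower number from compound 2 to compound 3 (0.82 log units; beyond the scatter) toward stronger inhibition. Compound 3 is estimated at 1500 nM with an expected range from 80 nM to 10000 nM overall.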

Compound 3, half-maximal inhibitory concentration in the HUVEC assay: > 10000 nM
Compound 3 ended at the assay's limit; the forecaster's own chance of this, stated with the estimate: 40%; middle value at least 6.6-fold (0.82 log units) away from the limit.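

In a physicochemical assay for solubility, at pH 6.8 (on this read-out higher numbers stand for higher solubility and lower numbers for lower solubility), compound 2 gives < 1000 nM, and this is a limit of the assay and not a number. In the physicochemical assay compound 3 gives < 1000 nM, and this is also a limit of the assay and not a number. Among these compounds, compound 2 and compound 3 both sit at limits in the HUVEC assay and in the physicochemical assay, so no step between them can be read. As far as these compounds go, whether pyridin-3-yl in place of methoxy shifts either read-out stays open.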